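Swapping the aryl group on the saturated ring carbon

A few compounds are considered here, and "the series" means these few. Any claim that something is new, unique, unknown or untested is made for them only; others in the source may bear on it.

Measured so far:
compound 1 `SC1=NC(n2nc(-c3ccccc3)nc2-c2ccccc2)=CC(c2ccc(Cl)cc2)N1` — 30 mg/kg
compound 2 `SC1=NC(n2nc(-c3ccccc3)nc2-c2ccccc2)=CC(c2ccccc2Cl)N1` — 30 mg/kg

Both values come from a functional assay on the whole organism with Mus musculus as the target, in the maximal electroshock model, with a stated time of 0.5 h; on this read-out lower numbers stand for an effect already at smaller amounts and higher numbers for an effect only at larger amounts of compound. Compound 1 stands level with compound 2 at the digits shown; the one step measured, no change at the digits printed from compound 1 to compound 2 (within the scatter), lies within the scatter. Compound 3 `COc1ccc(C2C=C(n3nc(-c4ccccc4)nc3-c3ccccc3)N=C(S)N2)c(OC)c1` differs from compound 1 as follows: 2,4-dimethoxyphenyl in place of 4-chlorophenyl on a saturated ring carbon. Among the compounds with values here, no measured step covers this change; the only step, no change at the digits printed from compound 1 to compound 2 (within the scatter), moved a chlorine between positions and showed no change. On that basis no shift beyond the scatter is expected, the step of no change at the digits printed from compound 1 to compound 3 (within the scatter) being the estimate. Compound 3 is therefore expected to give 30 mg/kg, between 15 mg/kg and 60 mg/kg.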

Compound 3, minimum effective dose: 30 mg/kg
The estimate for compound 3 equals the measured number at the digits printed, within the range that was stated.
By their numbers in this assay, from the lowest: compounds 1, 2 and 3 (each within the scatter of the next).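

In this assay, replacing either chlorophenyl group with 2,4-dimethoxyphenyl on this saturated ring carbon gives no change at the digits printed from compound 1 to compound 3 (within the scatter) and no change at the digits printed from compound 2 to compound 3 (within the scatter). The earlier pair only moved a chlorine, whereas here the chlorine is gone and the entering group has 10 heavy atoms against 7, plus 2 hydrogen-bond acceptors, yet the read-out holds. Nothing available explains why these exchanges leave the dose in place.

As far as these compounds go, whether this carbon needs an aromatic ring at all remains open. An amine, a carboxylic acid or a longer alkyl chain there could give a different result.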